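Aryl substituent swaps on the hydroxamate series

The source may report more compounds than this note shows. Statements on the series, on what has been measured and on what is new or still open speak of the compounds shown alone.

Values in a functional assay on ACHN cells (Homo sapiens) for inhibition, read by sulforhodamine B assay; on this read-out lower numbers stand for stronger inhibition of growth and higher numbers for weaker inhibition of growth:
compound 1 `O=C(CCC1=CCN(CCCc2ccc(Br)cc2)C1=O)NO`: 3330 nM
compound 2 `O=C(CCC1=CCN(CCCc2ccc(Cl)cc2)C1=O)NO`: 3330 nM
compound 3 `CCOc1ccc(CCCN2CC=C(CCC(=O)NO)C2=O)cc1`: 3330 nM

Compound 3 stands level with compounds 1 and 2; the steps of no change at the digits printed from compound 1 to compound 3 (within the scatter) and no change at the digits printed from compound 2 to compound 3 (within the scatter) are both within the scatter, as is no change at the digits printed from compound 1 to compound 2 (within the scatter). Compound 4 `CC(C)(C)c1ccc(CCCN2CC=C(CCC(=O)NO)C2=O)cc1` differs from compound 3 by tert-butyl in place of ethoxy on an aromatic carbon. Going by the values given here, the steps that bear on this are the two in which ethoxy entered in place of a halogen, and neither moved the read-out in this assay beyond the scatter. Another swap on the same aromatic carbon is therefore expected to give no step beyond the scatter in this assay. Compound 4 is expected at 3330 nM, with a range of 1100 nM to 10000 nM. The expected step is no change at the digits printed from compound 3 to compound 4 (within the scatter).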

Compound 4, concentration for 50% growth inhibition: 3330 nM
Estimate against measurement, compound 4: no gap at the digits printed, within the range that was stated.
By their numbers in this assay, from the lowest: compounds 1, 2, 3 and 4 (each within the scatter of the next).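

In this assay the all-carbon tert-butyl, with 4 heavy atoms and 0 hydrogen-bond acceptors, stands level with each earlier group on this aromatic carbon: ethoxy (no change at the digits printed from compound 3 to compound 4 (within the scatter)), chloro (no change at the digits printed from compound 2 to compound 4 (within the scatter)) and bromo (no change at the digits printed from compound 1 to compound 4 (within the scatter)). Among these four compounds, a hydrogen-bond acceptor in the group on this carbon is therefore not needed to keep the read-out at this level. Nothing at hand accounts for the flat read-out.

Going by these compounds, whether an amine, a carboxylic acid or a longer chain on this carbon would stay level remains open. So does the outcome with plain hydrogen there.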